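Swapping the Diethylamino Group of Compound 2

This account rests on a few compounds, and the source may have more. Where it says the series, first, only, none or still open, it means among the compounds named here.

In a functional assay on the whole organism for positive allosteric modulation, with Mus musculus as the target (a lower number here means that less compound is needed, a higher number that more compound is needed for the effect), compound 1 (`CCC(=O)N(c1cc(Cl)c(Cl)c(Cl)c1)C1CCCC1N(C)C`) gives 40 mg/kg as its dose, and compound 2 (`CCC(=O)N(c1ccc(Cl)c(Cl)c1)C1CCCC1N(CC)CC`) gives 0.3 mg/kg as its dose. Compound 2 therefore holds the lower of the two numbers, and its gap to compound 1 lies well beyond the scatter. These two compounds do not form a pair that differs in one place only.

Compound 3 (`CCC(=O)N(c1ccc(Cl)c(Cl)c1)C1CCCC1N(C)CCN(C)C`) departs from compound 2 at a single point, with (2-(dimethylamino)ethyl)(methyl)amino in place of diethylamino on a saturated ring carbon. Going by the values given here, no measured step shows what this replacement does, so the expectation is a loose one. Among the compounds with values here, it rests on compound 2 at 0.3 mg/kg being the lower of only two numbers, which leaves an expected drift toward more compound needed rather than less. The expected step is a 20-fold higher number from compound 2 to compound 3 (1.30 log units; beyond the scatter) toward a higher number, beyond the scatter. For compound 3 the estimate is 6 mg/kg with an expected range of 1 mg/kg to 40 mg/kg as the likely span.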

Compound 3, dose for half-maximal effect: 20 mg/kg
The estimate for compound 3 lay 3.3-fold (0.52 log units) below the measured number, within the range that was stated.
By their numbers in this assay, from the lowest: compound 2; then compounds 3 and 1 (each within the scatter of the next).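

In this assay, going by these compounds alone, putting (2-(dimethylamino)ethyl)(methyl)amino in place of diethylamino on a saturated ring carbon gives a 67-fold higher number from compound 2 to compound 3 (1.82 log units; beyond the scatter), and this is the first change in one place alone that can be read. It shows that this position of the five-membered ring is not indifferent to the amine it carries: with the dichlorophenyl amide and the rest of the core held constant, this exchange alone moves the dose needed by a large margin, well beyond the scatter. The material at hand offers nothing that would explain the size of this step.

The entering group differs from diethylamino both in its second nitrogen and in its longer chain, so the compounds shown leave open which of these two differences goes with the higher number. They also leave open how an all-carbon amine such as dipropylamino, or a ring amine such as pyrrolidine, would fare on the same saturated ring carbon, and whether any group there could give a lower number than diethylamino.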